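A few compounds are considered here, and "the series" means these few. Any claim that something is new, unique, unknown or untested is made for them only; others in the source may bear on it.

Of the compounds shown here, two have been measured. Compound 1 `O=C(Nc1ccc(I)cc1)c1cncc(N2CC3CC(C2)N3)c1` gives 0.366 nM in an assay on membranes from Cerebral cortex for displacement of a labelled ligand from Neuronal acetylcholine receptor; alpha4/beta2 (Rattus norvegicus); a lower number here means a stronger inhibitor, a higher number a weaker inhibitor. Compound 2 `O=C(Nc1cccc(F)c1)c1cncc(N2CC3CC(C2)N3)c1` gives 0.044 nM in the same test, and the change from one to the other, an 8.3-fold lower number from compound 1 to compound 2 (0.92 log units; beyond the scatter), is beyond the usual scatter. Among the measured compounds shown here, compound 2 therefore stands at the lowest of the two numbers, with compound 1 as its only neighbour, at a higher value beyond the scatter.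

Compound 3 `O=C(Nc1ccccc1F)c1cncc(N2CC3CC(C2)N3)c1` is not yet measured. Relative to compound 2 it carries 2-fluorophenyl in place of 3-fluorophenyl on an amide-type nitrogen. For the measured compounds named here, the single measured step bears on this only loosely: it changed both the halogen and its place on the ring at once, so it does not isolate what moving a fluorine alone does. Going by the values given here, with no measured step of that kind, the expectation rests on the observation that position on this ring mattered in the one step that exists, so a modest move is possible, most likely toward a higher number but perhaps within the scatter. For compound 3 the expected value is 0.12 nM, within a range from 0.03 nM to 0.5 nM. That estimate implies a step of a 2.7-fold higher number from compound 2 to compound 3 (0.44 log units; beyond the scatter), expected to be small.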

Compound 3, inhibition constant: 0.315 nM
Compound 3: the middle estimate sits 2.6-fold (0.42 log units) below what was measured; the measured number falls inside the stated range.
By their numbers in this assay, from the lowest: compound 2; then compounds 3 and 1 (each within the scatter of the next).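

In this assay, putting 2-fluorophenyl in place of 3-fluorophenyl on the amide-type nitrogen gives a 7.2-fold higher number from compound 2 to compound 3 (0.85 log units; beyond the scatter), so with the atoms unchanged, where the fluorine sits on this ring matters on its own, something the earlier step could not show because it changed the halogen and its place together. Set against 4-iodophenyl, 2-fluorophenyl gives a 1.2-fold lower number from compound 1 to compound 3 (0.07 log units; within the scatter), so these two groups cannot be told apart here, and among the three compounds only compound 2 stands apart, with its steps to both others beyond the scatter. Nothing measured here explains why the place of the fluorine counts for so much.

The compounds shown leave open how a fluorine would behave where compound 1 carries its iodine, which would complete the comparison of places on this ring. They also leave open whether the low number of compound 2 depends on fluorine itself, which a chlorine or a methoxy group in the same place, or a plain phenyl ring with no added group, would help to settle.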